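Cytotoxicity notes: hydrazone aryl swap, compound 1 to compound 4

The source may report more compounds than this note shows. Statements on the series, on what has been measured and on what is new or still open speak of the compounds shown alone.

The series shares a naphthyloxyacetyl hydrazone core with a varied aryl group on the carbon double-bonded to nitrogen. For the measured compounds named here, in an ADME assay on HEL cells (Homo sapiens) for cytotoxicity (on this read-out higher numbers stand for lower toxicity in this test and lower numbers for higher toxicity in this test), compound 1 `O=C(COc1cccc2ccccc12)N/N=C/c1ccc(Cl)cc1` gives 100 ug/mL, the highest of the three numbers so far. Compound 2 `C/C(=N\NC(=O)COc1cccc2ccccc12)c1cccc([N+](=O)[O-])c1` gives 10.5 ug/mL and compound 3 `C/C(=N\NC(=O)COc1cccc2ccccc12)c1ccccc1Br` gives 16.2 ug/mL, both well beyond the scatter below compound 1. Going by the values given here, the one step measured between neighbours, a 1.5-fold higher number from compound 2 to compound 3 (0.19 log units; within the scatter), exchanges one aryl group for another and stays within the scatter.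

Compound 4 `O=C(COc1cccc2ccccc12)N/N=C/c1ccccc1O` is obtained from compound 1 by the change (2-hydroxyphenyl in place of 4-chlorophenyl on a carbon with a double bond to nitrogen). Among the compounds with values here, no measured pair shows this particular exchange; the only aryl-for-aryl step available is that from compound 2 to compound 3, and it moved the read-out by nothing beyond the scatter. Compound 1 itself sits at the top of the range observed, which leaves more room downward than upward.

On that basis compound 4 is expected to stay close to compound 1, with a step of a 1.3-fold lower number from compound 1 to compound 4 (0.12 log units; within the scatter) that is not expected to exceed the scatter, though a modest drop is somewhat more likely than a rise. The estimate for compound 4 in this assay is 75 ug/mL, within 30 ug/mL to 150 ug/mL.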

Compound 4, half-maximal cytotoxic concentration: 3.57 ug/mL
Compound 4: middle estimate off by 21-fold (1.32 log units), on the high side; the measured number lies below the stated range.
By their numbers in this assay, from the lowest: compound 4; then compounds 2 and 3 (each within the scatter of the next); then compound 1.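

In this assay the aryl group on a carbon with a double bond to nitrogen proves able to move the read-out strongly: replacing 4-chlorophenyl with 2-hydroxyphenyl gives a 28-fold lower number from compound 1 to compound 4 (1.45 log units; beyond the scatter), so higher toxicity in this test follows this change on the core of compound 1. For the compounds shown here, the only earlier aryl exchange, a 1.5-fold higher number from compound 2 to compound 3 (0.19 log units; within the scatter), stayed within the scatter, so that step cannot be taken as a guide to every exchange at this place, even though the two groups here each hold 7 heavy atoms and one six-membered aromatic ring of carbon only. What separates them by count is the hydrogen-bond donor and acceptor on the entering 2-hydroxyphenyl, but no measurement in hand bears on why the number falls.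

The change alters both the substituent and where it sits on the ring, so the compounds shown leave open which of the two carries the step; 2-chlorophenyl or 4-hydroxyphenyl on the same carbon would separate them. Also open, going by these compounds, is whether 2-methoxyphenyl or 2-aminophenyl would give a number closer to that of compound 1 or of compound 4.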